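The source may report more compounds than this note shows. Statements on the series, on what has been measured and on what is new or still open speak of the compounds shown alone.

Notes on a series read in a physicochemical assay for solubility, with a stated time of 18 h, at pH 7.4 (on this read-out higher numbers stand for higher solubility and lower numbers for lower solubility), with a shared core varied at one aromatic carbon. Compound 1 `COc1cccc(CNCCCNc2ccnc3cc(C4CCCCC4)ccc23)c1O` carries cyclohexyl and gives 4200 nM as its reading. Compound 2 `COc1cccc(CNCCCNc2ccnc3cc(-c4ccc(F)cc4)ccc23)c1O` carries 4-fluorophenyl and gives 32000 nM on the same scale. Compound 3 `COc1ccc(Oc2ccc3c(NCCCNCc4cccc(OC)c4O)ccnc3c2)cc1` carries 4-methoxyphenoxy and gives 14500 nM as the second highest of the three numbers, with compound 2 nearest and compound 1 furthest.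

Next is compound 4 `CCC(CC)c1ccc2c(NCCCNCc3cccc(OC)c3O)ccnc2c1`, where the change from compound 3 is pentan-3-yl in place of 4-methoxyphenoxy on an aromatic carbon with pentan-3-yl in place of 4-methoxyphenoxy on an aromatic carbon.

Two measured steps leave cyclohexyl for a group with an aromatic ring: a 7.6-fold higher number from compound 1 to compound 2 (0.88 log units; beyond the scatter) and a 3.5-fold higher number from compound 1 to compound 3 (0.54 log units; beyond the scatter) both run upward. The step between the two aromatic groups is smaller, at a 2.2-fold lower number from compound 2 to compound 3 (0.34 log units; beyond the scatter) in this set. Cyclohexyl is the only measured group without an aromatic ring, which makes compound 1 at 4200 nM the closest guide, although every measured group has a ring and pentan-3-yl has none. Read backwards, a 3.5-fold higher number from compound 1 to compound 3 (0.54 log units; beyond the scatter) points to a modest drop in this assay of no more than that size. The estimated change is a 2.1-fold lower number from compound 3 to compound 4 (0.32 log units; beyond the scatter) on this evidence. For compound 4 the expected value is 7000 nM within an estimated range of 2500 nM to 20000 nM in this read-out.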

Compound 4, solubility: 4200 nM
Beside the measured number, compound 4's estimate is 1.7-fold (0.22 log units) above it; the range from low to high includes it.
By their numbers in this assay, from the lowest: compounds 1 and 4 (each within the scatter of the next); then compound 3; then compound 2.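

In this assay, for the compounds shown here, pentan-3-yl is the first group here with no ring at this aromatic carbon, and the reading stays level with the saturated ring, with no change at the digits printed from compound 1 to compound 4 (within the scatter), so the presence of a ring as such does not separate these two compounds. Going by these compounds alone, the steps to compound 4 from the two groups with an aromatic ring are larger, with a 3.5-fold lower number from compound 3 to compound 4 (0.54 log units; beyond the scatter) and a 7.6-fold lower number from compound 2 to compound 4 (0.88 log units; beyond the scatter), and across these four compounds both groups without an aromatic ring read lower than both groups with one, with no compound going against that split. The split remains a description only, as nothing measured here bears on what lies behind it.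

The compounds shown leave open whether the split follows the aromatic ring itself or the particular groups on it, which plain phenyl at the same carbon would help to separate. They also leave open how this read-out responds to a group carrying a different function, such as a piperidine amine, a carboxylic acid or a longer chain ending in a hydroxyl.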